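The source may hold more compounds than are shown below. What is called first, only, known or untested is meant among the compounds shown, and "the series" means these compounds.

Measured in a functional assay on MCF7 cells (Homo sapiens) for inhibition, read by sulforhodamine B assay, with a stated time of 48 h, tested at 50 uM; on this read-out higher numbers stand for more inhibition of growth at the one concentration tested and lower numbers for less inhibition of growth:
compound 1 `COc1ccc([C@@H]2C/C(=N/OCc3cn(-c4ccc(O)cc4)nn3)c3cc(CC=C(C)C)c(OC)cc3O2)cc1`: 63%
compound 2 `COc1ccc([C@@H]2C/C(=N/OCc3cn(-c4cc(OC)c(OC)c(OC)c4)nn3)c3cc(CC=C(C)C)c(OC)cc3O2)cc1`: 45%
compound 3 `COc1ccc([C@@H]2C/C(=N/OCc3cn(-c4ccc(C(N)=O)cc4)nn3)c3cc(CC=C(C)C)c(OC)cc3O2)cc1`: 100%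

Of these three, compound 3 stands highest, and its gaps to both others lie beyond the scatter. The next compound, compound 4 `COc1ccc([C@@H]2C/C(=N/OCc3cn(-c4cccnc4Cl)nn3)c3cc(CC=C(C)C)c(OC)cc3O2)cc1`, changes one group: 2-chloropyridin-3-yl in place of 4-carbamoylphenyl on an aromatic nitrogen. In words, this is 2-chloropyridin-3-yl in place of 4-carbamoylphenyl on an aromatic nitrogen.

All three measured steps concern this same group. The two that introduce 4-carbamoylphenyl are large: a number 37 percentage points higher from compound 1 to compound 3 (beyond the scatter), and a number 55 percentage points higher from compound 2 to compound 3 (beyond the scatter). The step between the other two groups is modest: a number 18 percentage points lower from compound 1 to compound 2 (beyond the scatter). Within the data shown here, no measured compound carries 2-chloropyridin-3-yl, so the estimate rests on an indirect comparison. Both measured compounds without the carbamoyl group lie well under compound 3, and a large downward step is therefore expected in this assay. The expected step is a number 40 percentage points lower from compound 3 to compound 4 (beyond the scatter). For compound 4 the estimated value is 60%, with an expected range from 35% to 88%.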

Compound 4, percent growth inhibition at one concentration: 35%
Beside the measured number, compound 4's estimate is 25 percentage points above it; low and high end bracket the measured number.
By their numbers in this assay, from the lowest: compounds 4 and 2 (each within the scatter of the next); then compound 1; then compound 3.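

In this assay, the 2-chloropyridin-3-yl group on the aromatic nitrogen loses most of the inhibition seen with 4-carbamoylphenyl (a number 65 percentage points lower from compound 3 to compound 4 (beyond the scatter)). Among these compounds, this is the first group at this position with a ring hetero atom, yet it does not separate from 3,4,5-trimethoxyphenyl (a number 10 percentage points lower from compound 2 to compound 4 (within the scatter)), while it stands under 4-hydroxyphenyl (a number 28 percentage points lower from compound 1 to compound 4 (beyond the scatter)). Among the four compounds, 4-carbamoylphenyl therefore remains the only group at this position that sets its compound apart from all the others, and nothing given here explains the differences.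

As far as these compounds go, it remains open whether a carboxylic acid or a nitrile in place of the carbamoyl group would keep the high inhibition. Also open, from the compounds shown here alone, is whether a plain pyridin-3-yl group would differ from 2-chloropyridin-3-yl.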